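The source may report more compounds than this note shows. Statements on the series, on what has been measured and on what is new or still open speak of the compounds shown alone.

In a functional assay on DU-145 cells (Homo sapiens) for cytotoxicity, read by trypan blue exclusion, with a stated time of 96 h (on this read-out lower numbers stand for stronger inhibition and higher numbers for weaker inhibition), compound 1 `COc1cc(OC)c(/C=C/S(=O)(=O)Nc2ccc(OC)c(N)c2)c(OC)c1` gives 5 nM, compound 2 `COC(=O)C(C)Nc1cc(NS(=O)(=O)/C=C/c2c(OC)cc(OC)cc2OC)ccc1OC` gives 100 nM and compound 3 `COC(=O)C(C)(C)Nc1cc(NS(=O)(=O)/C=C/c2c(OC)cc(OC)cc2OC)ccc1OC` gives 200 nM. Compound 3 therefore stands within the scatter of compound 2, and both lie far from compound 1. Substitution on the nitrogen accounts for the two large steps: a 20-fold higher number from compound 1 to compound 2 (1.30 log units; beyond the scatter) and a 40-fold higher number from compound 1 to compound 3 (1.60 log units; beyond the scatter). The step between the two substituted compounds, a 2.0-fold higher number from compound 2 to compound 3 (0.30 log units; within the scatter), is within the scatter.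

Compound 4 `COC(=O)C(Nc1cc(NS(=O)(=O)/C=C/c2c(OC)cc(OC)cc2OC)ccc1OC)c1ccccc1` carries methoxycarbonyl)(benzyl in place of 1-(methoxycarbonyl)-1-methylethyl on a nitrogen on an aromatic ring. The nitrogen stays substituted, so the large steps do not carry over, and the nearest guide is a 2.0-fold higher number from compound 2 to compound 3 (0.30 log units; within the scatter). Going by the values given here, no measured compound has an aromatic ring in this substituent, so the range stays wide. No change beyond the scatter is expected in this assay, and the expected step is a 1.3-fold higher number from compound 3 to compound 4 (0.10 log units; within the scatter). The estimate for compound 4 is 250 nM, with an expected range of 80 nM to 800 nM.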

Compound 4, half-maximal inhibitory concentration: 2500 nM
Beside the measured number, compound 4's estimate is 10-fold (1.00 log units) below it; measured number outside the range, above it.
By their numbers in this assay, from the lowest: compound 1; then compounds 2 and 3 (each within the scatter of the next); then compound 4.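

In this assay this position does not tolerate every substituent on the nitrogen: a 13-fold higher number from compound 3 to compound 4 (1.10 log units; beyond the scatter) is beyond the scatter, whereas the methyl added between compound 2 and compound 3 left the number within it. Phenyl in place of methyl on the same saturated chain carbon gives a 25-fold higher number from compound 2 to compound 4 (1.40 log units; beyond the scatter), so the size of this step depends on which group enters there, and the substituted compounds no longer form one tight group. With a 500-fold higher number from compound 1 to compound 4 (2.70 log units; beyond the scatter) as the largest step in the series, the data offer no measured account of why phenyl behaves so differently from methyl here.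

Going by these compounds, whether the distance from compound 1 follows the ester-bearing substituent or substitution on the nitrogen as such remains open. A plain ethyl on the nitrogen, or a carboxylic acid in place of the methyl ester, would separate these two readings.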